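Benzylamide in place of pyrrolidine on a bromophenyl thiophene

The compounds below may be only part of what the source reports. "The series", "measured", "known", "first", "only" and "open" are said of these compounds alone.

Of the compounds shown here, three of a shared core have been measured in a functional assay on PC-3 cells (Homo sapiens) for cytotoxicity, read by sulforhodamine B assay, with a stated time of 72 h; on this read-out lower numbers stand for stronger inhibition and higher numbers for weaker inhibition. Compound 1 `Nc1sc(-c2ccccc2)c(-c2ccc(Cl)cc2)c1C(=O)NCc1ccccc1` gives 22800 nM in this assay. Compound 2 `Nc1sc(-c2ccc(Br)cc2)c(-c2ccc(Cl)cc2)c1C(=O)NC1CC1` gives 37300 nM, and compound 3 `Nc1sc(-c2ccc(Br)cc2)c(-c2ccc(Cl)cc2)c1C(=O)N1CCCC1` gives 37500 nM. Compound 3 stands at the highest of the three numbers, but its gap to compound 2 and to compound 1 lies within the scatter, so no order can be read among them. Among the measured compounds shown here, the one comparable step, a 1.0-fold higher number from compound 2 to compound 3 (0.00 log units; within the scatter), shows that changing the amide substituent left the number unchanged. Compound 4 `Nc1sc(-c2ccc(Br)cc2)c(-c2ccc(Cl)cc2)c1C(=O)NCc1ccccc1` is the next member: benzylamino in place of pyrrolidin-1-yl on a carbonyl carbon. Compound 1 already carries the benzylamino group and differs from compound 4 only elsewhere in the molecule, and its value sits close to that of compound 3. Because the step of a 1.0-fold higher number from compound 2 to compound 3 (0.00 log units; within the scatter) was flat, the step from compound 3 to compound 4 is expected to be a 1.4-fold lower number from compound 3 to compound 4 (0.16 log units; within the scatter), no change beyond the scatter. Compound 4 is therefore estimated at 26000 nM, within a range of 10000 nM to 60000 nM.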

Compound 4, half-maximal inhibitory concentration: > 50000 nM
Compound 4: only a limit was reported (the forecaster's own chance of this, stated with the estimate: 10%); middle value at least 1.9-fold (0.28 log units) away from the limit.
By their numbers in this assay, from the lowest: compounds 1, 2 and 3 (each within the scatter of the next). At a limit, above all of these: compound 4.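

In this assay, compound 4 is reported only as a limit and not as a number: the limit of > 50000 nM in this assay, at which 1 of the 4 values shown sits. Among the compounds shown here, with benzylamino held constant on the carbonyl carbon, bromo in place of hydrogen on an aromatic carbon gives an at least 2.1-fold higher number from compound 1 to compound 4 (0.34 log units; beyond the scatter), the first step that lies beyond the scatter. At the amide, the steps are an at least 1.3-fold higher number from compound 3 to compound 4 (0.12 log units; that floor lies within the scatter) and an at least 1.3-fold higher number from compound 2 to compound 4 (0.12 log units; that floor lies within the scatter), so neither step shows a change beyond the scatter, and the aromatic bromo change is the only one here with a readable effect.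

On these data alone, it remains open whether bromo in place of hydrogen has the same effect when cyclopropylamino or pyrrolidin-1-yl sits on the carbonyl carbon. As far as these compounds go, it is also open how chloro or methoxy in that aromatic place, or morpholine on the carbonyl carbon, would read in this assay.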